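A few compounds are considered here, and "the series" means these few. Any claim that something is new, unique, unknown or untested is made for them only; others in the source may bear on it.

Among the compounds with values here, compound 2 `Cc1cccnc1-c1ccc(C(=O)Nc2ccc(C(F)(F)F)cc2)cc1` gives 81 nM in a functional assay for antagonist activity at transient receptor potential cation channel subfamily V member 1 (Rattus norvegicus) (on this read-out lower numbers stand for stronger inhibition and higher numbers for weaker inhibition), the higher of the two numbers measured so far, though only by a margin within the scatter. Compound 1 `Cc1cccnc1-c1ccc(C(=O)Nc2ccc(C(C)C)cc2)cc1` gives 43 nM in this assay. Within the data shown here, the single measured step is a 1.9-fold higher number from compound 1 to compound 2 (0.28 log units; within the scatter). The next compound is compound 3 `Cc1cccnc1-c1ccc(C(=O)Nc2ccc(C(C)(C)C)cc2)cc1`, which differs from compound 2 by tert-butyl in place of trifluoromethyl on an aromatic carbon. The step from compound 1 to compound 2 bears on it. Both compare an alkyl group with trifluoromethyl on the same aromatic carbon, isopropyl for compound 1 and tert-butyl for compound 3. Since that step was within the scatter, the change to compound 3 is expected to give a step of similar size in this assay, likely no larger than the scatter and running back toward the number of compound 1. The estimate for compound 3 in this assay is 45 nM, with a range of 15 nM to 150 nM. The step this implies is expected to be a 1.8-fold lower number from compound 2 to compound 3 (0.26 log units; within the scatter).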

Compound 3, half-maximal inhibitory concentration: 9 nM
For compound 3 the middle estimate is 5.0-fold (0.70 log units) above the measured one; measured number outside the range, below it.
By their numbers in this assay, from the lowest: compound 3; then compounds 1 and 2 (each within the scatter of the next).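

In this assay, this aromatic carbon, para to a large group, proves responsive to the choice of substituent: tert-butyl in place of trifluoromethyl gives a step beyond the scatter (a 9.0-fold lower number from compound 2 to compound 3 (0.95 log units; beyond the scatter)), which the earlier isopropyl and trifluoromethyl pair did not show. One added methyl on the saturated chain carbon of isopropyl also matters (a 4.8-fold lower number from compound 1 to compound 3 (0.68 log units; beyond the scatter)), leaving compound 3 with the lowest number of the series and steps beyond the scatter to both other compounds. Nothing available accounts for the gain from tert-butyl.

The compounds shown leave open whether the low number is specific to tert-butyl or extends to other groups at this position, such as a cyclohexyl ring, a methoxy group or an amine. They also leave open whether the same order of groups holds when the rest of the core changes.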